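Aryl ether exchange at the primary oxygen: compound 4

The source may hold more compounds than are shown below. What is called first, only, known or untested is meant among the compounds shown, and "the series" means these compounds.

Compound 1 `CO[C@@H]1O[C@H](COc2cccc(C(C)C)c2)[C@@H](O)[C@H](O)[C@H]1Oc1ccc(OC2CCCCC2)cc1` gives 40000 nM in a functional assay on MDA-MB-231 cells (Homo sapiens) for cytotoxicity, read by MTT assay, with a stated time of 48 h (on this read-out higher numbers stand for an effect only at larger amounts of compound and lower numbers for an effect already at smaller amounts), the highest of the three numbers, though its gap to each neighbour is within the scatter. Among the measured compounds shown here, compound 2 `CO[C@H]1O[C@H](COc2cccc(C(C)C)c2)[C@@H](O)[C@H](O)[C@H]1Oc1ccc(OC2CCCCC2)cc1` gives 38000 nM, and the only measured step, a 1.1-fold lower number from compound 1 to compound 2 (0.02 log units; within the scatter), rests on (the fact that compounds 1 and 2 differ only in the configuration as drawn). Compound 3 `CO[C@H]1O[C@H](COc2ccc(-c3ccccc3)cc2)[C@@H](O)[C@H](O)[C@H]1Oc1ccccc1C(C)C` gives 34000 nM and already carries the 4-phenylphenyl group that enters here. Compound 4 `CO[C@@H]1O[C@H](COc2ccc(-c3ccccc3)cc2)[C@@H](O)[C@H](O)[C@H]1Oc1ccc(OC2CCCCC2)cc1` differs from compound 1 by 4-phenylphenyl in place of 3-isopropylphenyl on an oxygen on a saturated carbon. For the measured compounds named here, no measured step covers this exchange; the values of compound 1 and compound 3 lie within the scatter of each other. No step beyond the scatter is therefore expected, and compound 4 is estimated at 37000 nM (range 18000 nM to 75000 nM), meaning an expected step of a 1.1-fold lower number from compound 1 to compound 4 (0.03 log units; within the scatter).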

Compound 4, half-maximal effective concentration: 36000 nM
Compound 4: the middle estimate sits 1.0-fold (0.01 log units) above what was measured, and the stated range covers the measured number.
By their numbers in this assay, from the lowest: compounds 3, 4, 2 and 1 (each within the scatter of the next).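

In this assay, among the compounds shown here, 4-phenylphenyl in place of 3-isopropylphenyl on an oxygen on a saturated carbon gives a 1.1-fold lower number from compound 1 to compound 4 (0.05 log units; within the scatter) as the one measured exchange at this position. A second aromatic ring and the larger carbon count therefore leave the read-out within the scatter. Nothing shown gives a cause for this result.

Open is whether a group of another kind at this position, such as an amine or a carboxylic acid, would give a number beyond the scatter of the compounds shown.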